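A Methoxy for Chloro Swap in an Inactive Series

The source may hold more compounds than are shown below. What is called first, only, known or untested is meant among the compounds shown, and "the series" means these compounds.

Compound 1, `O=c1ccoc2cc(OCc3cn(Cc4ccc(Cl)cc4)nn3)ccc12`, was tested in a functional assay on A549 cells (Homo sapiens) for cytotoxicity, read by MTT assay, with a stated time of 48 h; a lower number here means a stronger inhibitor, a higher number a weaker inhibitor. In this assay compound 1 gives > 100000 nM, which is a limit of the assay rather than a measured number. Two close relatives were run in the same test. Compound 2, `O=c1ccoc2cc(OCc3cn(Cc4cccc(F)c4)nn3)ccc12`, gives > 100000 nM in this assay, again only a limit. Compound 3, `CC(C)(C)c1ccc(Cn2cc(COc3ccc4c(=O)ccoc4c3)nn2)cc1`, gives > 100000 nM in this assay, also a limit. Putting 3-fluorophenyl in place of 4-chlorophenyl on a saturated chain carbon bound to an aromatic nitrogen reads as a step that the two limits leave unreadable from compound 1 to compound 2. Putting tert-butyl in place of chloro on an aromatic carbon reads as a step that the two limits leave unreadable from compound 1 to compound 3. What the three numbers share is the limit of > 100000 nM in this assay, at which 3 of the 3 values shown sit.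

Compound 4, `COc1ccc(Cn2cc(COc3ccc4c(=O)ccoc4c3)nn2)cc1`, differs from compound 1 by methoxy in place of chloro on an aromatic carbon. Among the measured compounds shown here, neither measured step touches this exact change, and both are unreadable anyway, so they give no size of step to lean on. Given (the limit of > 100000 nM in this assay, at which 3 of the 3 values shown sit), compound 4 is expected to remain at the limit as well, and the expected step is a step that the limit leaves unreadable from compound 1 to compound 4. Compound 4 is therefore estimated at 150000 nM, within a range from 50000 nM to 600000 nM.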

Compound 4, half-maximal inhibitory concentration: 16500 nM
Beside the measured number, compound 4's estimate is 9.1-fold (0.96 log units) above it; measured number below the stated range.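

In this assay, methoxy in place of chloro on an aromatic carbon, para to a large group, gives an at least 6.0-fold lower number from compound 1 to compound 4 (0.78 log units; beyond the scatter), whereas the steps among the first three compounds cannot be read. Methoxy in place of tert-butyl on that same carbon gives an at least 6.0-fold lower number from compound 3 to compound 4 (0.78 log units; beyond the scatter), and 4-methoxyphenyl in place of 3-fluorophenyl gives an at least 6.0-fold lower number from compound 2 to compound 4 (0.78 log units; beyond the scatter), so all three readable steps point the same way and each gives only a lower bound on its size. Compound 4 is the only one of the four with a measured number, which shows that a change in this one group can bring the series within the range of the test, against the picture left by the other three compounds: the limit of > 100000 nM in this assay, at which 3 of the 4 values shown sit.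

Among the compounds shown here, the true size of each step stays open, and with only one compound off the limit, these results do not tell whether the gain belongs to methoxy alone or would extend to other groups. Ethoxy, hydroxyl or dimethylamino on the same aromatic carbon would test how far the gain reaches, and the compounds shown do not cover them.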